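Arylpiperazine succinimide amides: fluoro in place of trifluoromethyl

The source may report more compounds than this note shows. Statements on the series, on what has been measured and on what is new or still open speak of the compounds shown alone.

In a functional assay on the whole organism (strain Swiss) with Mus musculus as the target, in the maximal electroshock model, with a stated time of 1 h, at a dose of 300 mg/kg by the intraperitoneal route (on this read-out higher numbers stand for a stronger effect at the one dose given and lower numbers for a weaker effect), compound 1 `COc1cccc(N2CCN(C(=O)C(C)N3C(=O)CCC3=O)CC2)c1` gives 0%. Compound 2 `CC(C(=O)N1CCN(c2ccc(C(F)(F)F)cc2)CC1)N1C(=O)CCC1=O` gives 0% in this assay and thus stands level with compound 1 at the digits recorded, within the scatter. Compound 3 `CC(C(=O)N1CCN(c2ccc(F)cc2)CC1)N1C(=O)CCC1=O` has not been measured in this assay. It differs from compound 2 by fluoro in place of trifluoromethyl on an aromatic carbon. Going by the values given here, no step between measured compounds exists here to build on, and both measured values sit at the floor of the read-out. The step is therefore expected to be no change at the digits printed from compound 2 to compound 3 (within the scatter), nothing beyond the scatter in either direction. Compound 3 is expected to give 0% in this assay, with a range from 0% to 25%.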

Compound 3, a percentage reported as activity, at one dose (the size of the read-out at that dose, not a potency): 25%
Beside the measured number, compound 3's estimate is 25 percentage points below it; low and high end bracket the measured number.
By their numbers in this assay, from the lowest: compounds 1 and 2 (each within the scatter of the next); then compound 3.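

In this assay the aromatic carbon para to a large group proves able to shift the read-out: fluoro in place of trifluoromethyl gives a number 25 percentage points higher from compound 2 to compound 3 (beyond the scatter), the first movement in the series. Against the other measured compound, 4-fluorophenyl in place of 3-methoxyphenyl on an amine nitrogen in a ring gives a number 25 percentage points higher from compound 1 to compound 3 (beyond the scatter), so only compound 3 stands clear of the other two. No measured data explain either step.

From the compounds shown here alone, whether chloro or a nitrile at this position would match fluoro remains open. So does whether a hydrogen there would keep the effect seen with compound 3.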